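Carrying the ethyl-to-hydrogen change onto the methylated core

The source may hold more compounds than are shown below. What is called first, only, known or untested is meant among the compounds shown, and "the series" means these compounds.

Compound 1, `CCOc1ccc(/C=C/c2cc(=O)c(O)c[nH]2)cc1`: 8120 nM
Compound 2, `O=c1cc(/C=C/c2ccc(O)cc2)[nH]cc1O`: 1730 nM
Compound 3, `CCOc1ccc(/C=C/c2cc(=O)c(O)cn2C)cc1`: 4020 nM

Of the compounds shown here, three have been measured in a functional assay, with a stated time of 10 min; a higher number here means a weaker inhibitor, a lower number a stronger inhibitor. Compound 1 gives 8120 nM, compound 2 gives 1730 nM, and compound 3 gives 4020 nM.

Two changes have been tested. Going from compound 1 to compound 2 the change is hydrogen in place of ethyl on an oxygen on an aromatic ring, and in this assay it gave a 4.7-fold lower number from compound 1 to compound 2 (0.67 log units; beyond the scatter). Going from compound 1 to compound 3 the change is methyl in place of hydrogen on an aromatic nitrogen, and it gave a 2.0-fold lower number from compound 1 to compound 3 (0.31 log units; beyond the scatter). Compound 3 thus stands second highest of the three numbers.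

Compound 4, `Cn1cc(O)c(=O)cc1/C=C/c1ccc(O)cc1`, has not yet been measured. It differs from compound 3 by hydrogen in place of ethyl on an oxygen on an aromatic ring. This is the same change as that from compound 1 to compound 2: the place is described in the same words in both cases, an oxygen on an aromatic ring whose other neighbours are aromatic carbon. The two cores differ by methyl in place of hydrogen on an aromatic nitrogen.

Since this change was seen once, the expectation for compound 4 rests on that single step. Because a 4.7-fold lower number from compound 1 to compound 2 (0.67 log units; beyond the scatter) was found when ethyl was replaced by hydrogen on compound 1, a step of similar size is expected here, so that the estimated step is a 4.7-fold lower number from compound 3 to compound 4 (0.67 log units; beyond the scatter). Compound 4 is therefore estimated at 860 nM in this assay, with a likely range from 400 nM to 1800 nM.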

Compound 4, half-maximal inhibitory concentration: 1370 nM
The estimate for compound 4 lay 1.6-fold (0.20 log units) below the measured number, and the stated range covers the measured number.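

In this assay, hydrogen in place of ethyl on the methylated core gave a 2.9-fold lower number from compound 3 to compound 4 (0.47 log units; beyond the scatter), and this step agrees with the one seen on the core of compound 1: the same change on two cores in this assay, a 4.7-fold lower number (0.67 log units; beyond the scatter) from compound 1 to compound 2 and a 2.9-fold lower number (0.47 log units; beyond the scatter) from compound 3 to compound 4, 1.6-fold (0.20 log units) apart, within the scatter of two such steps. Methyl in place of hydrogen on an aromatic nitrogen, read on the core of compound 2, gave a 1.3-fold lower number from compound 2 to compound 4 (0.10 log units; within the scatter), and this step also agrees with its earlier counterpart: the same change on two cores in this assay, a 2.0-fold lower number (0.31 log units; beyond the scatter) from compound 1 to compound 3 and a 1.3-fold lower number (0.10 log units; within the scatter) from compound 2 to compound 4, 1.6-fold (0.20 log units) apart, within the scatter of two such steps. Across these four compounds, each change thus carried from one core to the other with a size that held within the scatter, but each comparison rests on a single pair of cores, so this does not show that the same would hold on any other core, and it does not say why the steps have these sizes.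

The compounds shown leave open how a longer chain on that oxygen, or an amine in place of the ethoxy group, would read. They also leave open whether a chain longer than methyl on the aromatic nitrogen would follow the same course.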